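Halogenated aryl exchange on the shared core, intrinsic activity

A few compounds are considered here, and "the series" means these few. Any claim that something is new, unique, unknown or untested is made for them only; others in the source may bear on it.

Compound 1 `N=C(NCCCc1c[nH]cn1)NCCCC(c1ccc(F)cc1)c1ccccn1` carries a 4-fluorophenyl group on the chain carbon; in a functional assay on cardiac atrium for agonist activity at histamine H2 receptor (Cavia porcellus) (on this read-out lower numbers stand for smaller maximal responses and higher numbers for larger maximal responses), compound 1 gives 0.9. Compound 2 `N=C(NCCCc1c[nH]cn1)NCCC(c1ccc(C(F)(F)F)cc1)c1ccccn1` instead carries a 4-(trifluoromethyl)phenyl group there, and in this assay compound 2 gives 0.9. Compound 2 thus stands level with compound 1 at the digits shown, the two values lying within the scatter of each other, so no order between them can be read.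

Compound 3 `N=C(NCCCc1c[nH]cn1)NCCC(c1ccc(Cl)c(Cl)c1)c1ccccn1` has not been measured in this assay. It differs from compound 2 in one place: 3,4-dichlorophenyl in place of 4-(trifluoromethyl)phenyl on a saturated chain carbon bound to an aromatic carbon and a saturated chain carbon. Both measured compounds sit near the reference maximum, so for compound 3 the expected step of no change at the digits printed from compound 2 to compound 3 (within the scatter) is none beyond the scatter. For compound 3 the estimated value in this assay is 0.9, with a range from 0.7 to 1.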

Compound 3, intrinsic activity: the largest response reached, as a fraction of the reference agonist's: 1
The estimate for compound 3 lay 0.10 below the measured number; low and high end bracket the measured number.
By their numbers in this assay, from the lowest: compounds 1, 2 and 3 (each within the scatter of the next).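

In this assay the exchange of 4-(trifluoromethyl)phenyl for 3,4-dichlorophenyl on a saturated chain carbon bound to an aromatic carbon and a saturated chain carbon gives a number 0.10 higher from compound 2 to compound 3 (within the scatter) and thus no step beyond the scatter. For the compounds shown here, this is the first comparison between compounds that differ in one place, and it shows that this position tolerates the two halogenated aryl groups with the maximal response remaining near that of the reference agonist. No measurement on hand bears on the reason for this result.

On these data alone, whether the same position keeps this response with a group other than a halogenated aryl, such as unsubstituted phenyl or 4-aminophenyl, remains open. The compounds shown also leave open how the 3,4-dichlorophenyl group behaves on a longer chain.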